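The source may report more compounds than this note shows. Statements on the series, on what has been measured and on what is new or still open speak of the compounds shown alone.

Working notes on the series. Two compounds share one core and differ only in the group on the amide-type nitrogen. Compound 1 `O=C(NC1CCCC1)c1ccc(C#Cc2ccccc2)nc1` carries cyclopentyl there; in an assay on HEK293 cells for displacement of a labelled ligand from metabotropic glutamate receptor 5 (Homo sapiens), with a stated time of 2 h (a lower number here means a stronger inhibitor, a higher number a weaker inhibitor), compound 1 gives 3300 nM. Compound 2 `CNC(=O)c1ccc(C#Cc2ccccc2)nc1` carries methyl instead; in this assay compound 2 gives 15000 nM. Within the data shown here, the single step between them, a 4.5-fold higher number from compound 1 to compound 2 (0.66 log units; beyond the scatter), is modest but beyond the scatter. Among the measured compounds shown here, compound 2 therefore stands at the weaker end of the two numbers so far, with compound 1 as its nearest and only comparison.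

Compound 3 `CC(C)NC(=O)c1ccc(C#Cc2ccccc2)nc1` is not yet measured. It differs from compound 2 by isopropyl in place of methyl on an amide-type nitrogen. For the measured compounds named here, the one step that bears on this change is a 4.5-fold higher number from compound 1 to compound 2 (0.66 log units; beyond the scatter), in which the amide substituent other than methyl gave the lower number; the present change again moves away from methyl toward another alkyl group on the same nitrogen, though isopropyl is not cyclopentyl and no direct step for it exists. A lower number than that of compound 2 is thus expected, of a size not exceeding that step. For compound 3 the estimate is 6000 nM, within 2500 nM to 15000 nM, which means an expected step of a 2.5-fold lower number from compound 2 to compound 3 (0.40 log units; beyond the scatter) in this assay.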

Compound 3, inhibition constant: 7100 nM
Estimate against measurement, compound 3: 1.2-fold (0.07 log units) below, and the stated range covers the measured number.
By their numbers in this assay, from the lowest: compound 1; then compound 3; then compound 2.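

In this assay, the step for isopropyl in place of methyl on the amide-type nitrogen is a 2.1-fold lower number from compound 2 to compound 3 (0.32 log units; beyond the scatter), and that for isopropyl in place of cyclopentyl is a 2.2-fold higher number from compound 1 to compound 3 (0.33 log units; beyond the scatter). The earlier pair gave only two end points, whereas compound 3 now gives an intermediate point, so that among these three compounds the effect of this position is graded, with each step beyond the scatter and none going against the order cyclopentyl, isopropyl, methyl from the lowest number to the highest. Nothing available explains this order, and the three compounds alone give no basis for assigning it to any particular feature of these groups.

The compounds shown leave open how a longer chain such as n-butyl, or a group carrying a hydroxyl or a carboxylic acid, would stand on this nitrogen relative to the three alkyl groups. As far as these compounds go, all three compounds also share the same core, so it remains open whether the same order would hold with any other group elsewhere on that core.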